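This account rests on a few compounds, and the source may have more. Where it says the series, first, only, none or still open, it means among the compounds named here.

In a functional assay on MCF7 cells (Homo sapiens) for inhibition, read by fluorescence, with a stated time of 72 h (a lower number here means a stronger inhibitor, a higher number a weaker inhibitor), compound 1 `CC(C)n1cnc2c(NC(=N)N)nc(N)nc21` gives 97200 nM, compound 2 `CC(C)n1cnc2c(NC(=N)N)nc(NCCO)nc21` gives 12400 nM and compound 3 `CC[C@@H](CO)Nc1nc(NC(=N)N)c2ncn(C(C)C)c2n1` gives 1600 nM, the lowest of the three numbers. Compound 4 `CC(C)n1cnc2c(NC(=N)N)nc(OC[C@H]3CCCN3)nc21` differs from compound 3 at one place, on an aromatic carbon: (pyrrolidin-2-yl)methoxy in place of (1-(hydroxymethyl)propyl)amino on an aromatic carbon. The nearest guides are three measured steps at that same place: a 7.8-fold lower number from compound 1 to compound 2 (0.89 log units; beyond the scatter), a 7.8-fold lower number from compound 2 to compound 3 (0.89 log units; beyond the scatter) and a 61-fold lower number from compound 1 to compound 3 (1.78 log units; beyond the scatter). In these three compounds, a larger group went with a lower number. None of these steps brings in a ring or replaces the amino link with a methoxy link, so the size of the new step is uncertain. A modest rise in this assay is expected, and the expected step is a 1.6-fold higher number from compound 3 to compound 4 (0.19 log units; within the scatter). The estimated value for compound 4 is 2500 nM, within an expected range of 500 nM to 12000 nM.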

Compound 4, half-maximal inhibitory concentration: > 100000 nM
Compound 4 was reported as a limit (the forecaster's own chance of this, stated with the estimate: 5%); at least 40-fold (1.60 log units) between middle value and limit.
By their numbers in this assay, from the lowest: compound 3; then compound 2; then compound 1. At a limit, above all of these: compound 4.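

In this assay compound 4 gives > 100000 nM, which is a limit of the assay and not a number. Placing (pyrrolidin-2-yl)methoxy on this aromatic carbon gives an at least 62-fold higher number from compound 3 to compound 4 (1.79 log units; beyond the scatter), an at least 8.0-fold higher number from compound 2 to compound 4 (0.90 log units; beyond the scatter) and an at least 1.0-fold higher number from compound 1 to compound 4 (0.01 log units; that floor lies within the scatter). Compound 4 carries the largest group of the set and goes against the earlier link between a larger group and a lower number, so size alone does not set the result at this position.

The floor of the last of these steps lies within the scatter. On these data alone, whether the ring or the oxygen link drives the rise stays open, and a (pyrrolidin-2-yl)methylamino group, holding the ring on an amino link, would separate the two.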